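Swapping trifluoromethyl for fluoro in compound 2

The source may report more compounds than this note shows. Statements on the series, on what has been measured and on what is new or still open speak of the compounds shown alone.

Compound 1 `O=C1/C(=C/c2cccnc2)CN(S(=O)(=O)c2ccc(F)cc2)C/C1=C\c1ccccc1F`: 9900 nM
Compound 2 `O=C1/C(=C/c2cccnc2)CN(S(=O)(=O)c2ccc(C(F)(F)F)cc2)C/C1=C\c1ccccc1C(F)(F)F`: 1730 nM

In a functional assay on SMMC-7721 cells (Homo sapiens) for cytotoxicity, read by MTT assay, with a stated time of 24 h (a lower number here means a stronger inhibitor, a higher number a weaker inhibitor), compound 2 (1730 nM) has the lower of the two numbers, which makes it the stronger inhibitor so far, and its gap to compound 1 lies beyond the scatter of repeated measurements. Compound 3 `O=C1/C(=C/c2cccnc2)CN(S(=O)(=O)c2ccc(F)cc2)C/C1=C\c1ccccc1C(F)(F)F` is not yet measured. It differs from compound 2 in one place fluoro in place of trifluoromethyl on an aromatic carbon with fluoro in place of trifluoromethyl on an aromatic carbon, para to a large group. Among the compounds with values here, no measured pair shows this change on its own, so only the two known values can guide an expectation. A move from compound 2 toward compound 1 at 9900 nM is the likely direction, to a higher number but probably not the whole gap. The estimated change is a 2.3-fold higher number from compound 2 to compound 3 (0.36 log units; beyond the scatter) in this assay as a moderate weakening. Compound 3 is expected at 4000 nM (estimated range 1700 nM to 9500 nM).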

Compound 3, half-maximal inhibitory concentration: 6390 nM
For compound 3 the middle estimate is 1.6-fold (0.20 log units) below the measured one, and the stated range covers the measured number.
By their numbers in this assay, from the lowest: compound 2; then compounds 3 and 1 (each within the scatter of the next).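

In this assay the change to 4-fluorophenyl, taken alone, gives a 3.7-fold higher number from compound 2 to compound 3 (0.57 log units; beyond the scatter), so this aromatic carbon matters by itself, which the earlier pair could not show because compounds 1 and 2 differ in two places. The matching swap on the other fluorinated aromatic ring, with the 4-fluorophenyl group held fixed, gives a 1.5-fold lower number from compound 1 to compound 3 (0.19 log units; within the scatter), so that single change cannot be told apart from ordinary measurement noise. Nothing available explains why the two places behave differently. 

The compounds shown leave open whether a nitrile, a methoxy group or an amine on this aromatic carbon would keep the number of compound 2 or lose it as fluoro does. They also leave open whether the swap on the other ring would stay within the scatter with the 4-(trifluoromethyl)phenyl group in place.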